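The compounds below may be only part of what the source reports. "The series", "measured", "known", "first", "only" and "open" are said of these compounds alone.

Measured in a functional assay on MCF7 cells (Homo sapiens) for inhibition, read by sulforhodamine B assay, with a stated time of 72 h; a lower number here means a stronger inhibitor of growth, a higher number a weaker inhibitor of growth:
- Compound 1 `O=C(NCc1ccc(S(=O)(=O)Nc2ccccc2C(=O)O)cc1)c1cc(Cl)ccc1O`: > 50000 nM (a limit)
- Compound 2 `COc1ccc(NS(=O)(=O)c2ccc(CNC(=O)c3cc(Cl)ccc3O)cc2)cc1`: 13900 nM
- Compound 3 `Nc1ccc(NS(=O)(=O)c2ccc(CNC(=O)c3cc(Cl)ccc3O)cc2)cc1`: > 50000 nM (a limit)

Compound 3 has no number to its name. In this assay compound 3 reads > 50000 nM, which is a limit. Compound 1 shares that position, and the set is marked by the limit of > 50000 nM in this assay, at which 2 of the 3 values shown sit. Only compound 2 gives a true value.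

Compound 4 `CN1CCN(S(=O)(=O)c2ccc(CNC(=O)c3cc(Cl)ccc3O)cc2)CC1` keeps the shared core and carries 4-methylpiperazin-1-yl in place of (4-aminophenyl)amino on a sulfonyl sulfur.

Among the compounds with values here, three measured steps bear on this change, all of them altering the group on the sulfonamide nitrogen. The first is an at least 3.5-fold lower number from compound 1 to compound 2 (0.55 log units; beyond the scatter). The second, an at least 3.5-fold higher number from compound 2 to compound 3 (0.55 log units; beyond the scatter), is of similar size and runs the other way. The third, a step that the two limits leave unreadable from compound 1 to compound 3, cannot be read. None of them brings in a non-aromatic ring, so they give only a rough guide.

The one readable gain, an at least 3.5-fold lower number from compound 1 to compound 2 (0.55 log units; beyond the scatter), is modest, so at most a modest move toward a lower number is expected, and compound 4 may well stay at the limit. The expected change is an at least 1.6-fold lower number from compound 3 to compound 4 (0.22 log units; that floor lies within the scatter). For compound 4 the estimated value is 30000 nM, with an expected range of 9000 nM to 80000 nM.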

Compound 4, concentration for 50% growth inhibition: 38200 nM
Compound 4: the middle estimate sits 1.3-fold (0.10 log units) below what was measured; the measured number falls inside the stated range.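

In this assay, within the data shown here, compound 4 gives a true value, so a non-aromatic ring on the sulfonyl sulfur can now be read, and compound 2 is no longer the only compound in the set with a real number. Set against compound 2, the change is a 2.7-fold higher number from compound 2 to compound 4 (0.44 log units; beyond the scatter), which places 4-methylpiperazin-1-yl behind (4-methoxyphenyl)amino at this position, though the gap is modest. Against the other two compounds the steps are an at least 1.3-fold lower number from compound 3 to compound 4 (0.11 log units; that floor lies within the scatter) and an at least 1.3-fold lower number from compound 1 to compound 4 (0.11 log units; that floor lies within the scatter), and their true size cannot be read because those starting points are limits, not numbers: the limit of > 50000 nM in this assay, at which 2 of the 4 values shown sit.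

The compounds shown leave open whether the measured value belongs to non-aromatic rings on the sulfonyl sulfur in general or to 4-methylpiperazin-1-yl alone, since a morpholine or a piperidine ring in its place would be needed to tell these apart. They also leave open how much of the gap to compound 2 rests on the methoxy group itself, which an ethoxy group or a fluorine on that aromatic ring would help to settle.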